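A thiophene swap at the assay limit

This account rests on a few compounds, and the source may have more. Where it says the series, first, only, none or still open, it means among the compounds named here.

Measured in a functional assay on HCT-116 cells (Homo sapiens), read by MTT assay, with a stated time of 72 h; on this read-out lower numbers stand for stronger inhibition and higher numbers for weaker inhibition:
- Compound 1 `Nc1nc(N)c2c(-c3cccs3)cn([C@@H]3O[C@H](CO)[C@@H](O)[C@H]3O)c2n1`: > 20000 nM, a limit
- Compound 2 `Cc1nc(N)c2c(-c3ccco3)cn([C@@H]3O[C@H](CO)[C@@H](O)[C@H]3O)c2n1`: > 20000 nM, a limit
- Compound 3 `Cc1nc(N)c2c(-c3ccoc3)cn([C@@H]3O[C@H](CO)[C@@H](O)[C@H]3O)c2n1`: > 20000 nM, a limit

None of the three compounds yielded a number. Compound 3 gives > 20000 nM in this assay, and this is a limit. The whole set sits in the same place, with the limit of > 20000 nM in this assay, at which 3 of the 3 values shown sit.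

Compound 4 `Cc1nc(N)c2c(-c3cccs3)cn([C@@H]3O[C@H](CO)[C@@H](O)[C@H]3O)c2n1` has not yet been measured. It differs from compound 3 by one exchange: thiophen-2-yl in place of furan-3-yl on an aromatic carbon.

Within the data shown here, one measured step bears on this exchange, since it also swaps one five-membered aromatic ring for another: a step that the two limits leave unreadable from compound 2 to compound 3. Both of its ends are limits, so it offers no size to carry over. No step beyond the scatter can therefore be expected on the evidence of the limit of > 20000 nM in this assay, at which 3 of the 3 values shown sit, and no direction can be assigned. The estimated change is a number no higher from compound 3 to compound 4 (the limit leaves the size open), and this is an expectation only.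

Compound 4 is expected at 20000 nM, with an estimated range from 5000 nM to 40000 nM.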

Compound 4, half-maximal inhibitory concentration: > 20000 nM
Compound 4 ended at the assay's limit (the forecaster's own chance of this, stated with the estimate: 75%); the middle value lies on the limit itself.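

In this assay compound 4 also gives only a limit, so no step between it and compound 1, compound 2 or compound 3 can be read: the limit of > 20000 nM in this assay, at which 4 of the 4 values shown sit.

The compounds shown leave open whether any of these ring exchanges, or methyl in place of amino, changes the read-out at all.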